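Chain length and ring substitution at the isoindolinone-like core

The source may report more compounds than this note shows. Statements on the series, on what has been measured and on what is new or still open speak of the compounds shown alone.

Measured so far:
- compound 1, `CN1CCC[C@@H]1Cn1nc(Cc2ccc(C(C)(C)C)cc2)c2ccccc2c1=O`: > 1990 nM
- compound 2, `CN1CCC[C@@H]1Cn1nc(CCc2ccccc2)c2ccccc2c1=O`: 200 nM

Going by the values given here, in an assay for binding affinity to Alpha-1A adrenergic receptor (Homo sapiens) (on this read-out higher numbers stand for weaker inhibition and lower numbers for stronger inhibition), compound 2 gives 200 nM, and this is the only number available for the series. Compound 1 returns a limit, (the limit of > 1990 nM in this assay, at which 1 of the 2 values shown sits), not a number, so nothing can be said about the size of any step between the two.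

Compound 3, `CN1CCC[C@@H]1Cn1nc(Cc2ccc(F)cc2)c2ccccc2c1=O`, has not yet been measured. It differs from compound 2 by 4-fluorophenyl in place of benzyl on a saturated chain carbon bound to an aromatic carbon. Among the compounds with values here, compound 1 also carries a benzyl-type link to its aromatic ring, but with a tert-butyl group on that ring, and it sits at the limit; that gives no measured step to lean on. The shortening of the chain by one carbon is the larger part of the change, and its direction cannot be read from the two values shown.

Compound 3 is therefore expected to land somewhat weaker than compound 2, with a step of a 2.3-fold higher number from compound 2 to compound 3 (0.35 log units; beyond the scatter), and an estimated value of 450 nM, between 100 nM and 2000 nM.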

Compound 3, inhibition constant: 63.1 nM
Compound 3: the middle estimate sits 7.1-fold (0.85 log units) above what was measured; the measured number lies below the stated range.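

In this assay, going by these compounds alone, the change from benzyl to 4-fluorophenyl on a saturated chain carbon bound to an aromatic carbon, which reads as phenethyl to 4-fluorobenzyl when cut one bond further out, gives a 3.2-fold lower number from compound 2 to compound 3 (0.50 log units; beyond the scatter), the first measured step at this position, and it shows that the shorter 4-fluorobenzyl form does not cost affinity relative to phenethyl in this pair. With the chain held the same, fluoro in place of tert-butyl on an aromatic carbon gives an at least 31-fold lower number from compound 1 to compound 3 (1.49 log units; beyond the scatter), so the group on that ring has a large bearing on the reading. Compound 1 is a limit and not a number, so this step gives only a minimum size: the limit of > 1990 nM in this assay, at which 1 of the 3 values shown sits.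

The step from phenethyl to 4-fluorobenzyl combines a shorter chain with a new fluoro group, and only a plain benzyl or a 4-fluorophenethyl group on the shared core would separate the two contributions. Still open, from the compounds shown here alone, are how a chloro or methoxy group on the same ring would read against fluoro and tert-butyl, and how a chain longer than phenethyl would behave.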